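Hydroxy added to compound 1: expectation for compound 3

This account rests on a few compounds, and the source may have more. Where it says the series, first, only, none or still open, it means among the compounds named here.

- compound 1 `Oc1ccc2c(c1)CCc1ccc(O)c(c1)Oc1ccc(cc1)CCc1cccc(O)c1O2` gives 7980 nM in the measurements so far
- compound 2 `Oc1cc2c(cc1O)Oc1c(O)cccc1CCc1ccc(cc1)Oc1cc(ccc1O)CC2` gives 7510 nM in the same measurements

In a functional assay on HT-29 cells (Homo sapiens) for antiproliferative activity, read by MTT assay, with a stated time of 48 h (on this read-out lower numbers stand for stronger inhibition and higher numbers for weaker inhibition), only these two values exist, and they lie within the scatter of each other, so compound 1 has no distinct rank. Compound 3 `Oc1ccc2c(c1)CCc1ccc(O)c(c1)Oc1ccc(cc1O)CCc1cccc(O)c1O2` is not yet measured. It carries hydroxy in place of hydrogen on an aromatic carbon of the core of compound 1 (hydroxy in place of hydrogen on an aromatic carbon). Among the compounds with values here, the single measured step bearing on this is a 1.1-fold lower number from compound 1 to compound 2 (0.03 log units; within the scatter), the same kind of replacement at a different carbon. No measurement covers the carbon changed in compound 3, so the support is thin. No step beyond the scatter is therefore expected in this assay, in either direction. The expected step is a 1.1-fold lower number from compound 1 to compound 3 (0.03 log units; within the scatter) and remains an estimate. Compound 3 is estimated at 7500 nM, within an expected range from 3500 nM to 15000 nM.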

Compound 3, half-maximal inhibitory concentration: 15900 nM
Compound 3: the middle estimate sits 2.1-fold (0.33 log units) below what was measured, outside the stated range (above it).
By their numbers in this assay, from the lowest: compounds 2, 1 and 3 (each within the scatter of the next, the first and the last beyond it).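

In this assay, hydroxy in place of hydrogen on this aromatic carbon, ortho to a fused ring and meta to a fused ring, gives a 2.0-fold higher number from compound 1 to compound 3 (0.30 log units; within the scatter) and so stays inside the scatter, though at its edge. With a 1.1-fold lower number from compound 1 to compound 2 (0.03 log units; within the scatter) at a different carbon, two carbons of the core of compound 1 have now taken this replacement, and neither step lies beyond the scatter, so this position cannot yet be called sensitive to the change. No measurement bearing on the reason for the size of this step is available.

Open, from the compounds shown here alone, is whether a methoxy group or an amine on this same carbon would give a step beyond the scatter in this assay rather than one within it. Also open, going by these compounds, is whether a carboxylic acid there would behave as hydroxy does.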